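Changing the Group on the Ring Nitrogen: Cytotoxicity Outlook

The source may report more compounds than this note shows. Statements on the series, on what has been measured and on what is new or still open speak of the compounds shown alone.

Three measured compounds share one core and differ only in the group attached to an aromatic nitrogen. Compound 1 `COc1ccc(-n2nc(-c3ccc(C(F)(F)F)cc3O)nc2-c2ccccc2O)cc1` gives 98.9% in a functional assay on PC-12 cells (Rattus norvegicus) for cytotoxicity, read by MTT assay, with stated times of 2 h and 24 h, tested at 10 uM; on this read-out lower numbers stand for a weaker effect and higher numbers for a stronger effect at the one concentration tested. Compound 2 `Oc1cc(C(F)(F)F)ccc1-c1nc(-c2ccccc2O)n(-c2ccccc2C(F)(F)F)n1` gives 92.2% in this assay, and compound 3 `Oc1cc(C(F)(F)F)ccc1-c1nc(-c2ccccc2O)n(-c2ccc(F)cc2F)n1` gives 97.9%. On these numbers compound 3 stands second highest of the three; its nearest neighbour is compound 1 and its furthest is compound 2, and both gaps lie within the scatter, so no order among the three can be claimed.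

Compound 4 `Cc1cc(C)cc(-n2nc(-c3ccc(C(F)(F)F)cc3O)nc2-c2ccccc2O)c1` has not yet been measured. It differs from compound 3 by 3,5-dimethylphenyl in place of 2,4-difluorophenyl on an aromatic nitrogen. Every measured step concerns exactly this position, and all three were small: a number 6.7 percentage points lower from compound 1 to compound 2 (within the scatter), a number 1 percentage points lower from compound 1 to compound 3 (within the scatter) and a number 5.7 percentage points higher from compound 2 to compound 3 (within the scatter). None of these exchanges moved the read-out beyond the scatter. A further exchange at the same position is not expected to do so either. The step of a number 1.9 percentage points lower from compound 3 to compound 4 (within the scatter) is thus expected to stay small. Compound 4 is estimated at 96% in this assay, within a range from 87% to 100%.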

Compound 4, a percentage reported as activity, at one concentration (the size of the read-out at that concentration, not a potency): 105%
Compound 4: middle estimate off by 9 percentage points, on the low side, outside the stated range (above it).
By their numbers in this assay, from the lowest: compounds 2, 3, 1 and 4 (each within the scatter of the next, the first and the last beyond it).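

In this assay, among the compounds shown here, this position now gives one step that clears the usual scatter (a number 12.8 percentage points higher from compound 2 to compound 4 (beyond the scatter)), the only such step among the four compounds, so the choice of group on the aromatic nitrogen can make a modest difference to the read-out. That separation holds for just this one pair, as the other two new steps stay small (a number 7.1 percentage points higher from compound 3 to compound 4 (within the scatter); a number 6.1 percentage points higher from compound 1 to compound 4 (within the scatter)), and compound 4 therefore cannot be placed apart from compound 1 or compound 3. Nothing at hand explains why 3,5-dimethylphenyl and 2-(trifluoromethyl)phenyl differ in this way.

All four compounds shown carry a substituted phenyl ring on this nitrogen, so it stays open whether a group of another kind, such as a longer alkyl chain, or a phenyl ring bearing an amine or a carboxylic acid, would give a larger step. Each compound also has a reading at a single concentration only, which leaves open how the differences would look across a range of concentrations.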